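Replacing a Hydroxy Group with Ureido on the Sulfur Chain

The compounds below may be only part of what the source reports. "The series", "measured", "known", "first", "only" and "open" are said of these compounds alone.

Measured compounds:
compound 1, `CC(C)c1n[nH]c2c(NCc3ccc(-c4ccccn4)cc3)nc(SCCO)nc12`: 48 nM
compound 2, `CC(C)c1n[nH]c2c(NCc3ccc(-c4ccccn4)cc3)nc(SC(C)C(C)O)nc12`: 190 nM
compound 3, `CC(C)c1n[nH]c2c(NCc3ccc(-c4ccccn4)cc3)nc(SC3CCCCC3O)nc12`: 636 nM

The three compounds share one core and differ only in the group carried on a sulfur. In a functional assay on HT cells (Homo sapiens) for antiproliferative activity, read by fluorescence, with a stated time of 72 h (on this read-out higher numbers stand for weaker inhibition of growth and lower numbers for stronger inhibition of growth), compound 1 gives the lowest number of the three, so it is the strongest inhibitor of growth here: the steps of a 4.0-fold higher number from compound 1 to compound 2 (0.60 log units; beyond the scatter) and a 13-fold higher number from compound 1 to compound 3 (1.12 log units; beyond the scatter) are both beyond the scatter, as is a 3.3-fold higher number from compound 2 to compound 3 (0.52 log units; beyond the scatter).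

Compound 4, `CC(C)c1n[nH]c2c(NCc3ccc(-c4ccccn4)cc3)nc(SCCNC(N)=O)nc12`, has not been measured. Its change from compound 1 is ureido in place of hydroxy on a saturated chain carbon, two bonds along the chain from a sulfur. The measured steps each replace 2-hydroxyethyl with a larger group on the sulfur and each weakens inhibition, the larger the group the more so, but none of them tests a ureido or a change two bonds along the chain from the sulfur. Going by those steps, a modest weakening is expected, a 2.5-fold higher number from compound 1 to compound 4 (0.40 log units; beyond the scatter). Compound 4 is therefore estimated at 120 nM, with a range from 40 nM to 400 nM.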

Compound 4, concentration for 50% growth inhibition: 240 nM
Compound 4: middle estimate off by 2.0-fold (0.30 log units), on the low side, within the range that was stated.
By their numbers in this assay, from the lowest: compound 1; then compounds 2 and 4 (each within the scatter of the next); then compound 3.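

In this assay, a 5.0-fold higher number from compound 1 to compound 4 (0.70 log units; beyond the scatter) shows that the sulfur chain can lose activity without any added branch or ring: the change here is confined to the end of a 2-hydroxyethyl group, on a saturated chain carbon two bonds along the chain from the sulfur. The step of a 1.3-fold higher number from compound 2 to compound 4 (0.10 log units; within the scatter) leaves the 2-ureidoethyl and 2-hydroxy-1-methylpropyl groups indistinguishable in this assay. By contrast, a 2.7-fold lower number from compound 3 to compound 4 (0.42 log units; beyond the scatter) places the 2-ureidoethyl group clearly ahead of 2-hydroxycyclohexyl, so the new group falls within the range already set by the hydroxy-bearing groups, and the 2-hydroxyethyl group of compound 1 still gives the strongest inhibition of the four.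

No measurement shown explains these differences. On these data alone, whether an amine, a carboxylic acid or a longer chain ending in hydroxy would match the 2-hydroxyethyl group remains open.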